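The source may hold more compounds than are shown below. What is called first, only, known or untested is meant among the compounds shown, and "the series" means these compounds.

Compound 1 `CCCCNc1nc(C(F)(F)F)ccc1CNC(=O)C(C)c1ccc(NS(C)(=O)=O)c(F)c1` gives 293 nM in a functional assay on CHO-K1 cells for antagonist activity at transient receptor potential cation channel subfamily V member 1 (Homo sapiens), read by FLIPR; a higher number here means a weaker inhibitor, a lower number a stronger inhibitor.
Compound 2 `CC1CCC(Nc2nc(C(F)(F)F)ccc2CNC(=O)C(C)c2ccc(NS(C)(=O)=O)c(F)c2)CC1` gives 1130 nM in this assay.
Compound 3 `CC(C(=O)NCc1ccc(C(F)(F)F)nc1N1CCC(C(=O)c2ccc(F)cc2)CC1)c1ccc(NS(C)(=O)=O)c(F)c1` gives 990 nM in this assay.

Among these three numbers compound 3 stands second highest. Its nearest neighbour is compound 2, whose value lies within the scatter of that of compound 3, so the two cannot be ordered; compound 1 lies further off, beyond the scatter, with the lower number of the two. Among the compounds with values here, the only measured step, a 3.9-fold higher number from compound 1 to compound 2 (0.59 log units; beyond the scatter), concerns a change on the amine nitrogen of the shared core and is modest in size.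

Compound 4 `CC(=O)OC1CCN(c2nc(C(F)(F)F)ccc2CNC(=O)C(C)c2ccc(NS(C)(=O)=O)c(F)c2)CC1` differs from compound 3 in one place: acetoxy in place of (4-fluorophenyl)carbonyl on a saturated ring carbon. Within the data shown here, no measured step covers this exchange, and the step from compound 1 to compound 2 touches a different part of the molecule, so it offers only a sense of how far such changes have moved the numbers so far. On that basis compound 4 is expected to stay close to compound 3, with a step of a 1.2-fold lower number from compound 3 to compound 4 (0.09 log units; within the scatter) in this assay. The estimate for compound 4 is 800 nM, within a range from 250 nM to 2500 nM.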

Compound 4, half-maximal inhibitory concentration: 139 nM
Compound 4: middle estimate off by 5.8-fold (0.76 log units), on the high side, outside the stated range (below it).
By their numbers in this assay, from the lowest: compound 4; then compound 1; then compounds 3 and 2 (each within the scatter of the next).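

At the saturated ring carbon, three ring bonds from the ring nitrogen, the exchange of (4-fluorophenyl)carbonyl for acetoxy gives a 7.1-fold lower number from compound 3 to compound 4 (0.85 log units; beyond the scatter) in this assay, the first sign that this position moves the number at all. The full 4-acetoxypiperidin-1-yl group gives an 8.1-fold lower number from compound 2 to compound 4 (0.91 log units; beyond the scatter) when it replaces (4-methylcyclohexyl)amino and a 2.1-fold lower number from compound 1 to compound 4 (0.32 log units; beyond the scatter) when it replaces butylamino, yet compound 3 carries the same ring without the low number, so here the group on the ring counts, not the ring alone. Nothing available accounts for these differences.

From the compounds shown here alone, it remains open whether the lower number belongs to the acetoxy group as such or would also appear with a hydroxyl or methoxy group on that ring carbon. Also open, going by these compounds, is how an amide or a carboxylic acid would fare there.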